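Chloro to Methoxy on a Growth Inhibitor

The compounds below may be only part of what the source reports. "The series", "measured", "known", "first", "only" and "open" are said of these compounds alone.

In a functional assay on T47D cells (Homo sapiens) for inhibition (on this read-out higher numbers stand for weaker inhibition of growth and lower numbers for stronger inhibition of growth), compound 1 (`COc1cc(/C=C/C(=O)c2cccc(-n3cc(-c4ccc(Cl)cc4)[nH]c3=O)c2)cc(OC)c1OC`) gives 6650 nM and compound 2 (`O=C(/C=C/c1cccc(O)c1)c1cccc(-n2cc(-c3ccccc3)[nH]c2=O)c1`) gives 4240 nM. These two values lie within the usual scatter of repeated measurements, so compound 1 stands level with compound 2. Compound 3 (`COc1ccc(-c2cn(-c3cccc(C(=O)/C=C/c4cc(OC)c(OC)c(OC)c4)c3)c(=O)[nH]2)cc1`) has not yet been measured. It keeps the core of compound 1 and changes one place, 4-chlorophenyl to 4-methoxyphenyl: methoxy in place of chloro on an aromatic carbon. This puts methoxy in place of chloro on an aromatic carbon, para to a large group. Going by the values given here, no measured pair shows this change alone, so the expectation rests on compound 1 at 6650 nM. No step beyond the scatter is expected in this assay, and neither direction is favoured. The expected step is a 1.3-fold lower number from compound 1 to compound 3 (0.12 log units; within the scatter). For compound 3, the estimated value is 5000 nM, within an expected range of 1800 nM to 14000 nM.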

Compound 3, concentration for 50% growth inhibition: 3840 nM
Compound 3: the middle estimate sits 1.3-fold (0.11 log units) above what was measured; the range from low to high includes it.
By their numbers in this assay, from the lowest: compounds 3, 2 and 1 (each within the scatter of the next).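

In this assay the swap of 4-chlorophenyl for 4-methoxyphenyl gives a step that stays within the scatter (a 1.7-fold lower number from compound 1 to compound 3 (0.24 log units; within the scatter)), so compound 1 and compound 3 stand level. Going by these compounds alone, this is the first pair here that isolates a single change, and it shows that this place, on an aromatic carbon para to a large group, accepts methoxy in place of chloro without a clear shift in growth inhibition, even though methoxy adds a heavy atom and a hydrogen-bond acceptor. Nothing measured here bears on why the two groups read alike.

The compounds shown leave open whether a group of another kind at this place, such as an amine, a carboxylic acid or a longer chain, would move the number beyond the scatter. One pair also cannot tell whether the same swap would read alike on a different core.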